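From a hydroxy to a benzyloxy group

The source may hold more compounds than are shown below. What is called first, only, known or untested is meant among the compounds shown, and "the series" means these compounds.

Measured so far (a functional assay on HepG2 cells (Homo sapiens) for inhibition, read by WST assay, with stated times of 72 h and 2 h; a lower number here means a stronger inhibitor, a higher number a weaker inhibitor)
Compound 1 (`OC(c1cccs1)c1cc2ccccc2nc1Cl`) gives 80800 nM
Compound 2 (`Cc1ccc(-c2cc(COC(c3cccs3)c3cc4ccccc4nc3Cl)on2)cc1`) gives "not active" (no number reported)

Going by the values given here, compound 1 holds the only number in this small set, so it cannot yet be ranked as strong or weak against anything else. Compound 2 was tested but came back without a number, and that outcome cannot be turned into a step.

Compound 3 (`Clc1nc2ccccc2cc1C(OCc1ccccc1)c1cccs1`) differs from compound 1 in one place (benzyl in place of hydrogen on an oxygen on a saturated carbon). It has benzyl in place of hydrogen on an oxygen on a saturated carbon, which can also be read as hydroxy to benzyloxy.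

Among the compounds with values here, no pair of measured compounds shows how large such a change might be in this assay, so there is little to build on. The safest expectation is no step beyond the scatter, with a real chance that compound 3 also returns no number. The estimate is a small move, a 1.2-fold lower number from compound 1 to compound 3 (0.06 log units; within the scatter) and this expected step has no firm direction. Compound 3 is expected at 70000 nM within an estimated range from 20000 nM to 200000 nM for now.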

Compound 3, half-maximal inhibitory concentration: "not active" (no number reported)
Compound 3 has no reported number here; no gap can be computed for the estimate.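

In this assay, going by these compounds alone, compound 3 returned no number, so no step from compound 1 to compound 3 can be read. No available evidence bears on this result. With compound 1 at 80800 nM as the only number, the compounds shown leave open how far the change from hydroxy to benzyloxy shifts activity.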